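An ester replaces the amide of compound 3

The source may report more compounds than this note shows. Statements on the series, on what has been measured and on what is new or still open speak of the compounds shown alone.

Among the measured compounds shown here, in an ADME assay on Vero cells (Chlorocebus sabaeus) for cytotoxicity, read by MTT assay, with a stated time of 48 h (on this read-out higher numbers stand for weaker inhibition and lower numbers for stronger inhibition), compound 3 `O=C(NC1CCC(CN2CCN(c3cc(=O)c4cc(C(F)(F)F)cc([N+](=O)[O-])c4s3)CC2)CC1)c1ccccc1` gives 44.3 ug/mL, the only exact number so far. Compound 1 `CCCC(=O)OC1CCC(CN2CCN(c3cc(=O)c4cc(C(F)(F)F)cc([N+](=O)[O-])c4s3)CC2)CC1` is reported only as a limit, > 64 ug/mL. Compound 2 `O=C(OC1CCC(CN2CCN(c3cc(=O)c4cc(C(F)(F)F)cc([N+](=O)[O-])c4s3)CC2)CC1)c1cccc(C(F)(F)F)c1` is also reported only as a limit, > 64 ug/mL.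

Compound 4 `COc1ccccc1C(=O)OC1CCC(CN2CCN(c3cc(=O)c4cc(C(F)(F)F)cc([N+](=O)[O-])c4s3)CC2)CC1` differs from compound 3 at one place (((2-methoxyphenyl)carbonyl)oxy in place of benzamido on a saturated ring carbon), with ((2-methoxyphenyl)carbonyl)oxy in place of benzamido on a saturated ring carbon. For the measured compounds named here, two measured steps bear on this change. The closer one is an at least 1.4-fold lower number from compound 1 to compound 3 (0.15 log units; that floor lies within the scatter), with benzamido in place of (propylcarbonyl)oxy, which is the reverse kind of swap. The other is a step that the two limits leave unreadable from compound 1 to compound 2, with 3-(trifluoromethyl)phenyl in place of propyl on a carbonyl carbon. Compound 4 has a carbonyl-oxy link like compound 1, so undoing that closer step points to a somewhat higher number in this assay. The expected change is a 1.4-fold higher number from compound 3 to compound 4 (0.16 log units; within the scatter), a modest rise close to the usual scatter. For compound 4, the estimated value is 64 ug/mL, with an expected range of 35 ug/mL to 128 ug/mL.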

Compound 4, half-maximal inhibitory concentration: > 64 ug/mL
Compound 4 was reported as a limit (the forecaster's own chance of this, stated with the estimate: 60%); the middle value sits exactly at the limit.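

Compound 4 is reported only as a limit, > 64 ug/mL. Setting ((2-methoxyphenyl)carbonyl)oxy in place of benzamido gives an at least 1.4-fold higher number from compound 3 to compound 4 (0.15 log units; that floor lies within the scatter), so this second comparison between the benzamido compound and a carbonyl-oxy compound, now with an aromatic ring on both sides, again cannot be told apart from the scatter. Compound 4 also shows that a third group on the carbonyl carbon, 2-methoxyphenyl, leaves the carbonyl-oxy series at one shared result: the limit of > 64 ug/mL in this assay, at which 3 of the 4 values shown sit.

The steps among compound 1, compound 2 and compound 4 cannot be read, so any differences among these three stay hidden behind the limit. Also open, going by these compounds, is what a simple amine or a carboxylic acid on the same saturated ring carbon would give in this assay.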